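This account rests on a few compounds, and the source may have more. Where it says the series, first, only, none or still open, it means among the compounds named here.

Compound 1 `Cc1cn(C)c(=O)n(/C=C/C=O)c1=O`: 15000 nM
Compound 2 `Cc1cn(/C=C/C#N)c(=O)[nH]c1=O`: > 100000 nM

In a functional assay on HeLa cells (Homo sapiens) for inhibition (a higher number here means a weaker inhibitor, a lower number a stronger inhibitor), compound 1 gives 15000 nM, a measured number. Compound 2 gives > 100000 nM, which is a limit of the assay and not a number, and it stands at the limit of > 100000 nM in this assay, at which 1 of the 2 values shown sits.

The next compound to be tested is compound 3 `Cc1cn(/C=C/C=N/O)c(=O)[nH]c1=O`. Relative to compound 2, the cyano group leaves and a group with no common name enters, on a double-bonded chain carbon bound to a double-bonded chain carbon: a group of 3 heavy atoms (1 carbon, 1 nitrogen, 1 oxygen; no ring) in place of a group of 2 heavy atoms (1 carbon, 1 nitrogen; no ring), on a double-bonded chain carbon bound to a double-bonded chain carbon.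

No measured step between two of these compounds is available as a guide. Among the measured compounds shown here, the only measured number is that of compound 1 at 15000 nM, and the expectation leans towards it. The estimated change an at least 2.0-fold lower number from compound 2 to compound 3 (0.30 log units; that floor lies within the scatter) is expected to point towards a stronger inhibitor, by a moderate amount, although compound 3 may well end at the limit too. For compound 3 in this assay, the expected half-maximal inhibitory concentration is 50000 nM, with an estimated range from 12000 nM to 100000 nM.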

Compound 3, half-maximal inhibitory concentration: > 100000 nM
Compound 3: only a limit was reported; the forecaster's own chance of this, stated with the estimate: 45%; middle value at least 2.0-fold (0.30 log units) away from the limit.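

In this assay, compound 2 and compound 3 each give a limit of the assay and not a number, so the step between them cannot be read: the limit of > 100000 nM in this assay, at which 2 of the 3 values shown sit.

The compounds shown leave open whether putting the group of 3 heavy atoms in place of the cyano group changes inhibition at all.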